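Ring nitrogen substituent: isopropyl to cyclohexyl

A few compounds are considered here, and "the series" means these few. Any claim that something is new, unique, unknown or untested is made for them only; others in the source may bear on it.

Compound 2 `CC(C)N1CCc2nc(C#Cc3ccccn3)ccc2C1=O` holds the lowest number of the two measured in a functional assay on HEK293 cells for negative allosteric modulation of metabotropic glutamate receptor 5 (Homo sapiens), read by FLIPR and calcium flux; on this read-out lower numbers stand for stronger inhibition and higher numbers for weaker inhibition: compound 2 gives 27 nM. Within the data shown here, its only comparator is compound 1 `CN1CCc2nc(C#Cc3ccccn3)ccc2C1=O`, where compound 1 gives 184 nM. Among the measured compounds shown here, the one measured step, a 6.8-fold lower number from compound 1 to compound 2 (0.83 log units; beyond the scatter), shows a larger alkyl group on the amide-type nitrogen in the ring going with a lower number.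

Compound 3 `O=C1c2ccc(C#Cc3ccccn3)nc2CCN1C1CCCCC1` changes the same position again: cyclohexyl in place of isopropyl on an amide-type nitrogen in a ring. The step from compound 1 to compound 2 is the only one that bears on this change, and it was modest but beyond the scatter. A second enlargement at the same nitrogen might continue in the same direction, but nothing measured shows whether the gain carries on, levels off or reverses; a smaller further drop, or a change within the scatter, is the expectation.

Compound 3 is therefore estimated at 15 nM in this assay, with a range from 5 nM to 60 nM, the expected step being a 1.8-fold lower number from compound 2 to compound 3 (0.26 log units; within the scatter).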

Compound 3, half-maximal inhibitory concentration: 518 nM
For compound 3 the middle estimate is 35-fold (1.54 log units) below the measured one; measured number outside the range, above it.
By their numbers in this assay, from the lowest: compound 2; then compound 1; then compound 3.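

In this assay the substituent on the ring nitrogen follows no simple order of group size: the gain from methyl to isopropyl does not carry on to cyclohexyl, with a 19-fold higher number from compound 2 to compound 3 (1.28 log units; beyond the scatter), and the number ends up past that of the methyl compound, with a 2.8-fold higher number from compound 1 to compound 3 (0.45 log units; beyond the scatter). The link between a larger alkyl group and a lower number therefore holds only for the pair of compound 1 and compound 2, compound 3 goes against it, and of the three groups isopropyl gives the lowest number. Nothing available here accounts for this reversal.

Cyclohexyl differs from isopropyl both in its carbon count and in having a ring, so the two changes cannot be separated, and a longer open chain such as n-pentyl alongside a small ring such as cyclopropyl would bear on that question. Also open, going by these compounds, is where between isopropyl and cyclohexyl the number turns upward, for which cyclobutyl and cyclopentyl would be the closest groups, and whether tetrahydropyranyl, with a ring oxygen, behaves like cyclohexyl.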